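Exchanging the Bicyclic Group on a Weak Antiproliferative Series

A few compounds are considered here, and "the series" means these few. Any claim that something is new, unique, unknown or untested is made for them only; others in the source may bear on it.

Measured compounds:
compound 1 `O=C1NC(O)(CCn2cnc3cncc(Br)c32)C(OCc2ccccc2)=C1OCc1ccccc1` – 66500 nM
compound 3 `O=C1O/C(=C\Cn2cnc3cncc(Br)c32)C(OCc2ccccc2)=C1OCc1ccccc1` – 46900 nM
compound 2 `O=C1O/C(=C\Cn2cnc3ccn(C/C=C4\OC(=O)C(OCc5ccccc5)=C4OCc4ccccc4)c3c2=O)C(OCc2ccccc2)=C1OCc1ccccc1` – a limit of the assay, > 100000 nM

All three were tested in a functional assay on HepG2 cells (Homo sapiens) for antiproliferative activity, read by MTT assay, with a stated time of 72 h; a higher number here means a weaker inhibitor, a lower number a stronger inhibitor. In this assay compound 1 gives 66500 nM, and compound 3 gives 46900 nM; these two numbers lie within the scatter of each other, so neither can be called the more or less potent. The value of compound 2 is not a number but a limit, (the limit of > 100000 nM in this assay, at which 1 of the 3 values shown sits). Taken together, the series is only weakly active, and no step between two measured compounds that differ in a single place is available to guide expectations.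

Compound 4 `Nc1nc(F)c(Cl)c2c1ncn2CCC1(O)NC(=O)C(OCc2ccccc2)=C1OCc1ccccc1` is not yet measured. It differs from compound 1 in one place: a group of 12 heavy atoms (6 carbon, 4 nitrogen, 1 fluorine, 1 chlorine; one five-membered aromatic ring with 2 hetero atoms, one six-membered aromatic ring with 1 hetero atom) in place of a group of 10 heavy atoms (6 carbon, 3 nitrogen, 1 bromine; one five-membered aromatic ring with 2 hetero atoms, one six-membered aromatic ring with 1 hetero atom), on a saturated chain carbon, two bonds along the chain from a saturated ring carbon. The change brings an added hydrogen-bond donor and acceptor, but without a measured step of this kind, the expectation rests only on the narrow spread of the measured values. The step from compound 1 to compound 4 is expected to be small, a 1.3-fold lower number from compound 1 to compound 4 (0.12 log units; within the scatter), in no clear direction beyond the scatter. Compound 4 is therefore estimated at 50000 nM, with a range from 15000 nM to 150000 nM.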

Compound 4, half-maximal inhibitory concentration: > 100000 nM
Compound 4 gave a limit, no number; the forecaster's own chance of this, stated with the estimate: 25%; middle value at least 2.0-fold (0.30 log units) from the limit.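

In this assay compound 4 gives > 100000 nM, which is a limit of the assay and not a number. Among these compounds, this exchange on a saturated chain carbon, two bonds along the chain from a saturated ring carbon, provides the first step that changes a single place: an at least 1.5-fold higher number from compound 1 to compound 4 (0.17 log units; that floor lies within the scatter). On these data alone, its true size stays unknown, and since only its floor is printed, the step gives no sign that the entering group, with its added hydrogen-bond donor and acceptor, improves on the group that leaves, while the limit now recurs: the limit of > 100000 nM in this assay, at which 2 of the 4 values shown sit.

As far as these compounds go, the exchange alters several atoms at once, so the part played by the bromine, fluorine, chlorine or added nitrogens cannot be separated, and whether the same exchange would behave alike on the core of compound 3 also stays open. Nor do these compounds show what a simple phenyl ring, a carboxylic acid or a longer chain would do in this place, so it remains unknown whether any group here can move the series clearly beyond its weak range.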